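Ortho-methyl on the N-phenyl ring of compound 1

This account rests on a few compounds, and the source may have more. Where it says the series, first, only, none or still open, it means among the compounds named here.

Compound 1 `COc1cc2c(Oc3ccc(NC(=O)c4nn(-c5ccccc5)c(=O)cc4C)cc3F)ccnc2cc1OCCCN1CCCC1` is the reference point of this pair. In a functional assay on HT-29 cells (Homo sapiens) for inhibition, read by MTT assay, with a stated time of 72 h (on this read-out higher numbers stand for weaker inhibition and lower numbers for stronger inhibition), compound 1 gives 220 nM. Among the measured compounds shown here, its only measured neighbour is compound 2 `COc1cc2c(Oc3ccc(NC(=O)c4nn(-c5ccccc5)c(=O)cc4C)cc3F)ccnc2cc1OCCCN1CCCCC1`, which in this assay gives 160 nM; the step of a 1.4-fold lower number from compound 1 to compound 2 (0.14 log units; within the scatter) concerns the amine at the end of the three-carbon chain and stays within the scatter, so the two numbers cannot be ordered.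

Compound 3 `COc1cc2c(Oc3ccc(NC(=O)c4nn(-c5ccccc5C)c(=O)cc4C)cc3F)ccnc2cc1OCCCN1CCCC1` has not been measured. It differs from compound 1 by methyl in place of hydrogen on an aromatic carbon. For the measured compounds named here, no measured step touches the phenyl ring on the pyridazinone part of the core; the single step recorded, from the pyrrolidine to the piperidine at the chain end, is elsewhere in the molecule and small, so it offers no direct guide to this change. With nothing pointing either way, a step no larger than the scatter is the working expectation.

Compound 3 is therefore estimated at 250 nM in this assay, with a range of 80 nM to 800 nM. The step this implies, a 1.1-fold higher number from compound 1 to compound 3 (0.06 log units; within the scatter), is expected to stay within the usual scatter.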

Compound 3, half-maximal inhibitory concentration: 1400 nM
Beside the measured number, compound 3's estimate is 5.6-fold (0.75 log units) below it, and the stated range ends below it.
By their numbers in this assay, from the lowest: compounds 2 and 1 (each within the scatter of the next); then compound 3.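

Of the two steps now on record, this is the one that leaves the scatter: in this assay, methyl in place of hydrogen on an aromatic carbon of the phenyl ring, ortho to a large group, gives a 6.4-fold higher number from compound 1 to compound 3 (0.80 log units; beyond the scatter). The change adds a single heavy atom, so the phenyl ring on the core of compound 1 responds to a very small substitution, whereas the swap of pyrrolidin-1-yl for piperidin-1-yl at the chain end, a 1.4-fold lower number from compound 1 to compound 2 (0.14 log units; within the scatter), gave two numbers that cannot be ordered. Nothing measured on this series speaks to the reason for the rise at this place.

One methyl cannot show whether the loss belongs to that group alone or to any substituent on this ring carbon, and a fluorine, a chlorine or a methoxy group at the same place would separate the two readings. On these data alone, it also remains open whether the same methyl on the phenyl ring would give a step of similar size with the piperidin-1-yl chain end of compound 2.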